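The compounds below may be only part of what the source reports. "The series", "measured", "known", "first", "only" and "open" are said of these compounds alone.

Measured in an in vitro ADME assay on microsomes from liver (Mus musculus) for metabolic stability, read by LC-MS, tested at 3 uM; a lower number here means that the compound disappears faster, a higher number that the compound lasts longer:
- compound 1 `CN1C[C@H]2CCCC[C@@]2(Cc2ccc(Cl)c(Cl)c2)C1`: 0.417 h
- compound 2 `CN1C[C@@H]2CCC[C@]2(c2ccc3ccccc3c2)C1`: 0.3 h
- compound 3 `Clc1ccc([C@@]23CCCC[C@@H]2CNC3)cc1Cl`: > 5 h (a limit of the assay)

Compound 3 stands at > 5 h, which is a limit and not a number. This is the only such case among the three: the limit of > 5 h in this assay, at which 1 of the 3 values shown sits.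

Compound 4 `Clc1ccc([C@]23CCCC[C@H]2CNC3)cc1Cl` is the mirror image of compound 3: the two compounds have the same atoms and bonds and differ only in configuration as drawn: 2 of 2 stereo elements differ (all stereocentres are inverted: mirror images); a stereocentre at a saturated ring carbon is drawn R in compound 3 and S in compound 4; a stereocentre at a saturated ring carbon is drawn S in compound 3 and R in compound 4. Within the data shown here, the measured compounds include no pair of mirror images, so the expectation rests on compound 3 alone, with its limit of > 5 h. A moderate fall in this assay is expected, an at least 1.2-fold lower number from compound 3 to compound 4 (0.09 log units; that floor lies within the scatter), and a reading at the same limit remains possible. For compound 4 the estimated half-life is 4 h, with an expected range of 1.2 h to 8 h.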

Compound 4, half-life: > 5 h
Compound 4: no number, only a limit; the forecaster's own chance of this, stated with the estimate: 45%; middle value at least 1.2-fold (0.09 log units) from the limit.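

Compound 4, like compound 3, gives only a limit in this assay, so no step between the two can be read: the limit of > 5 h in this assay, at which 2 of the 4 values shown sit.

On these data alone, whether these mirror images, compound 3 and compound 4, differ in half-life at all, and by how much, stays open.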